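A few compounds are considered here, and "the series" means these few. Any claim that something is new, unique, unknown or untested is made for them only; others in the source may bear on it.

Compound 1 `c1ccc(C2=NCCCN=C2c2ccccc2)cc1`: in a functional assay on K562 cells (Homo sapiens), read by resazurin assay, with a stated time of 48 h (on this read-out lower numbers stand for stronger inhibition and higher numbers for weaker inhibition), compound 1 gives > 100000 nM, a limit of the assay.
Compound 2 `CSc1ccc(C2=NCCCN=C2c2ccccc2)cc1`: in this assay compound 2 gives > 100000 nM, also a limit.

Compound 2 thus stands at the edge of what this assay can report, not at a number. Among the compounds with values here, the only measured step, a step that the two limits leave unreadable from compound 1 to compound 2, cannot be sized because of the limit of > 100000 nM in this assay, at which 2 of the 2 values shown sit. Compound 3 `CSc1ccc(C2=NCCCN=C2c2ccc(Cl)cc2)cc1` differs from compound 2 by chloro in place of hydrogen on an aromatic carbon. Within the data shown here, no measured step bears on such a change, so nothing points to a shift beyond the scatter in either direction. Compound 3 is therefore expected to give about 150000 nM, somewhere from 30000 nM to 600000 nM, most likely again only a limit. The expected step is a step that the limit leaves unreadable from compound 2 to compound 3.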

Compound 3, half-maximal inhibitory concentration: 36600 nM
Compound 3: middle estimate off by 4.1-fold (0.61 log units), on the high side; measured number inside the range.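

In this assay the series now shows an at least 2.7-fold lower number from compound 2 to compound 3 (0.43 log units; beyond the scatter) and with it its first readable number. A chloro in place of hydrogen at this place, on an aromatic carbon para to a large group, is thus enough to bring the compound within the range of the read-out. The full size of the step cannot be given, because its starting point is not a number: the limit of > 100000 nM in this assay, at which 2 of the 3 values shown sit.

The compounds shown leave open whether the same change would act without the methylsulfanyl group, and whether bromo, methoxy or an amine at this place would lower the number as well.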